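A Fluorobutyl Chain on the Ring Nitrogen

This account rests on a few compounds, and the source may have more. Where it says the series, first, only, none or still open, it means among the compounds named here.

Compound 2 `COc1ccc(F)cc1-c1cccc(-c2n[nH]c(=O)o2)c1` gives 49% in a functional assay on the whole organism (strain Wistar albino) for inhibition, with Rattus norvegicus as the target, read by paw edema, with stated times of 30 min and 1.5 h, at a dose of 10 mg/kg by the oral route (a lower number here means less inhibition, a higher number more inhibition at the dose given (going by the name of the read-out)), the lowest of the two numbers in hand; its nearest neighbour, compound 1 `COc1ccc(F)cc1-c1cccc(-c2nn(CCCC#N)c(=O)o2)c1`, gives 59%, and the step of a number 10 percentage points lower from compound 1 to compound 2 (within the scatter) lies within the scatter. Compound 3 `COc1ccc(F)cc1-c1cccc(-c2nn(CCCCF)c(=O)o2)c1` has not yet been measured. It differs from compound 2 by 4-fluorobutyl in place of hydrogen on an aromatic nitrogen. Going by the values given here, the one step that bears on this change, a number 10 percentage points lower from compound 1 to compound 2 (within the scatter), also exchanged a chain on the aromatic nitrogen for hydrogen and stayed within the scatter, so no shift beyond the scatter is expected here either. Compound 3 is therefore estimated at 55%, between 40% and 70%, a step of a number 6 percentage points higher from compound 2 to compound 3 (within the scatter).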

Compound 3, a percentage reported as inhibition, in the whole organism at one dose (the size of the read-out at that dose, not a potency): 67%
Estimate against measurement, compound 3: 12 percentage points below; the range from low to high includes it.
By their numbers in this assay, from the lowest: compounds 2, 1 and 3 (each within the scatter of the next, the first and the last beyond it).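

On the aromatic nitrogen, 4-fluorobutyl in place of hydrogen gives a step beyond the scatter in this assay (a number 18 percentage points higher from compound 2 to compound 3 (beyond the scatter)), which the earlier pair with 3-cyanopropyl did not show. Fluoromethyl in place of cyano, three bonds along the chain from that nitrogen, stays within the scatter (a number 8 percentage points higher from compound 1 to compound 3 (within the scatter)), so these two chains cannot be told apart here. Nothing available explains why adding the 4-fluorobutyl chain raises the number.

From the compounds shown here alone, whether a longer chain on this nitrogen would go further remains open. So does whether an amine or a carboxylic acid on the chain would keep the effect.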